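Swapping the bicyclic amine substituent for an aminopyrimidine

A few compounds are considered here, and "the series" means these few. Any claim that something is new, unique, unknown or untested is made for them only; others in the source may bear on it.

Three compounds have been characterised in an assay on Sf9 cells for inhibition of N6-adenosine-methyltransferase catalytic subunit (Homo sapiens), read by TR-FRET; a lower number here means a stronger inhibitor, a higher number a weaker inhibitor. Compound 1 `CC1(C)CCN(Cc2ccc(N3CC(=O)NC4(CCN(c5ccnc6[nH]ccc56)CC4)C3)cc2)CC1` gives 4500 nM in this assay. Compound 2 `CNc1cc(N2CCC(O)(CNc3ccc(CN4CCC(C)(C)CC4)nc3)CC2)ncn1` gives 5800 nM, and compound 3 `CNc1cc(N2CCCC(O)(CNC(=O)c3ccc(CN4CCC(C)(C)CC4)cc3)C2)ncn1` gives 7000 nM. Compound 1 sits at the low end of these three numbers, but its gaps to compound 2 and to compound 3 both lie within the usual scatter of repeated measurements, so the three are not distinguishable on this evidence.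

Compound 4 `CC(C)Nc1cc(N2CCC3(CC2)CN(c2ccc(CN4CCC(C)(C)CC4)cc2)CC(=O)N3)ncn1` has not yet been measured. It differs from compound 1 by a group of 10 heavy atoms (7 carbon, 3 nitrogen; one six-membered aromatic ring with 2 hetero atoms) in place of a group of 9 heavy atoms (7 carbon, 2 nitrogen; one five-membered aromatic ring with 1 hetero atom, one six-membered aromatic ring with 1 hetero atom), on an amine nitrogen in a ring. Compound 2 and compound 3 each carry a methylaminopyrimidinyl group on a ring amine and give numbers close to that of compound 1, which suggests that such an exchange at this position carries little weight. The step from compound 1 to compound 4 is therefore expected to be a 1.1-fold higher number from compound 1 to compound 4 (0.05 log units; within the scatter), with no direction beyond the scatter. For compound 4 the estimate in this assay is 5000 nM, expected to fall between 2000 nM and 12000 nM.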

Compound 4, half-maximal inhibitory concentration: 330 nM
Compound 4: middle estimate off by 15-fold (1.18 log units), on the high side; measured number outside the range, below it.
By their numbers in this assay, from the lowest: compound 4; then compounds 1, 2 and 3 (each within the scatter of the next).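

In this assay, the exchange gives this position its first direct reading: replacing the group with a five-membered and a six-membered aromatic ring by 6-(isopropylamino)pyrimidin-4-yl, on the amine nitrogen of the six-membered ring, brings a 14-fold lower number from compound 1 to compound 4 (1.13 log units; beyond the scatter). On this core, then, the group on that nitrogen weighs heavily on the number. The three earlier compounds differ from one another in more than one place and offer no step, so their closeness could not show this, and nothing available bears on why the number falls so far.

Going by these compounds, whether the pyrimidine ring or its isopropylamino group carries the step remains open, since both enter together. Also open, on these data alone, is whether a plain amino group or a cyclopropylamino group on that ring would keep the lower number.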